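This account rests on a few compounds, and the source may have more. Where it says the series, first, only, none or still open, it means among the compounds named here.

In a functional assay on HeLa cells (Homo sapiens) for antiproliferative activity, read by MTT assay, with a stated time of 72 h (on this read-out lower numbers stand for stronger inhibition and higher numbers for weaker inhibition), compound 1 `O=C1COc2ccc(-c3cnc4ccccc4c3)cc2N1C1CCCCC1` gives 19700 nM as a measured number. Compound 2 `Cc1ccc(N2C(=O)COc3ccc(-c4cnc5ccccc5c4)cc32)cc1` stands at > 40000 nM as a limit of the assay and not a number. Among the measured compounds shown here, the one measured step is an at least 2.0-fold higher number from compound 1 to compound 2 (0.30 log units; that floor lies within the scatter) and it exchanges the whole group on the ring nitrogen, so it bears only weakly on the next change. Compound 3 `O=C1COc2ccc(-c3cnc4ccccc4c3)cc2N1c1ccc(F)cc1` differs by fluoro in place of methyl on an aromatic carbon and reads as fluoro in place of methyl on an aromatic carbon. No step beyond the scatter is expected in this assay and the estimate means an at least 1.0-fold lower number from compound 2 to compound 3 (0.02 log units; that floor lies within the scatter) as the expected step. Compound 3 is estimated at 38000 nM within an expected range of 18000 nM to 70000 nM and may again report only a limit.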

Compound 3, half-maximal inhibitory concentration: 38800 nM
The estimate for compound 3 lay 1.0-fold (0.01 log units) below the measured number, and the stated range covers the measured number.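

With 4-fluorophenyl on the ring nitrogen, compound 3 gives a number where compound 2 gave none, so an aryl group in place of cyclohexyl can now be sized in this assay, and the step stays within the scatter: a 2.0-fold higher number from compound 1 to compound 3 (0.29 log units; within the scatter). Compound 2 holds a limit of the assay and not a number: the limit of > 40000 nM in this assay, at which 1 of the 3 values shown sits.

From the compounds shown here alone, the change from 4-methylphenyl to 4-fluorophenyl therefore has only a floor, and its true size stays unknown: an at least 1.0-fold lower number from compound 2 to compound 3 (0.01 log units; that floor lies within the scatter). Open, going by these compounds, is whether an amine or a carboxylic acid on this phenyl ring, or a longer chain on the ring nitrogen, would move the number beyond the scatter from compound 1.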